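Amide variation and 5-hydroxytryptamine receptor 1D binding

The source may report more compounds than this note shows. Statements on the series, on what has been measured and on what is new or still open speak of the compounds shown alone.

Compound 1, `CCCCCCCC(=O)Nc1ccc2[nH]cc(C3CCN(C)CC3)c2n1`: 110 nM
Compound 2, `CN1CCC(c2c[nH]c3ccc(NC(=O)C4CC4)nc23)CC1`: 1800 nM
Compound 3, `CN1CCC(c2c[nH]c3ccc(NC(=O)c4ccc([N+](=O)[O-])cc4)nc23)CC1`: 340 nM

Three compounds sharing one core and differing only in the group on the amide carbonyl have been measured in an assay for binding affinity to 5-hydroxytryptamine receptor 1D (Homo sapiens), read by radioligand binding; on this read-out higher numbers stand for weaker inhibition and lower numbers for stronger inhibition. Compound 3, carrying the 4-nitrophenyl group, stands second highest of the three numbers; its nearest neighbour is compound 1 with the heptyl chain, reached by a 3.1-fold higher number from compound 1 to compound 3 (0.49 log units; beyond the scatter), and its furthest is compound 2 with the cyclopropyl group, reached by a 5.3-fold lower number from compound 2 to compound 3 (0.72 log units; beyond the scatter). The step of a 16-fold higher number from compound 1 to compound 2 (1.21 log units; beyond the scatter) is the largest of the set.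

Compound 4, `CN1CCC(c2c[nH]c3ccc(NC(=O)c4ccncc4)nc23)CC1`, has not yet been measured in this assay. It differs from compound 3 by pyridin-4-yl in place of 4-nitrophenyl on a carbonyl carbon. For the measured compounds named here, no measured step exchanges one aromatic group for another, so the steps that bear on this change do so only loosely: both aryl and cyclopropyl groups gave higher numbers than the heptyl chain, and the 4-nitrophenyl sat between the two. The account therefore expects compound 4 to lie in the same broad region as compound 3 and compound 2, with a step of a 1.9-fold higher number from compound 3 to compound 4 (0.28 log units; within the scatter) expected, and the number for compound 4 in this assay is estimated at 650 nM, within a range from 200 nM to 2200 nM.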

Compound 4, inhibition constant: 420 nM
Compound 4: the middle estimate sits 1.5-fold (0.19 log units) above what was measured; the range from low to high includes it.
By their numbers in this assay, from the lowest: compound 1; then compounds 3 and 4 (each within the scatter of the next); then compound 2.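

In this assay, for the compounds shown here, the change from 4-nitrophenyl to pyridin-4-yl on the carbonyl carbon gives the first exchange of one aromatic group for another at this position, and a 1.2-fold higher number from compound 3 to compound 4 (0.09 log units; within the scatter) places the two compounds within the scatter of each other, although the entering ring holds a hetero atom and the leaving ring holds none. The pyridin-4-yl amide also stands apart from both non-aromatic amides, with a 4.3-fold lower number from compound 2 to compound 4 (0.63 log units; beyond the scatter) and a 3.8-fold higher number from compound 1 to compound 4 (0.58 log units; beyond the scatter), so the separation that compound 3 showed from compound 1 and compound 2 is now seen with a second aromatic group. Nothing available on these compounds gives a reason for this result.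

The compounds shown leave open whether an unsubstituted phenyl, a pyridin-3-yl or a pyridin-2-yl group on the carbonyl carbon would keep the number in the same region, or whether a methoxy group or an amine on the ring would shift it. They also leave open how butyl, hexyl or a longer chain would compare with the heptyl chain of compound 1.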